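Cyclopropyl for Allyl on the Amide Nitrogen

The source may hold more compounds than are shown below. What is called first, only, known or untested is meant among the compounds shown, and "the series" means these compounds.

Of the compounds shown here, two have been tested in a toxicity assay on the whole organism (strain Icem-CET (SPF Caw)) for cytotoxicity, with Mus musculus as the target; on this read-out higher numbers stand for an effect only at larger amounts of compound and lower numbers for an effect already at smaller amounts. Compound 1 `C/C(C(=O)NC1CC1)=C(/C)c1ccc(F)cc1` carries a cyclopropyl on its amide nitrogen and a fluorine on the aromatic ring; in this assay compound 1 gives 110 mg/kg. Compound 2 `C=CCNC(=O)/C(C)=C(\C)c1ccc(C)cc1` carries an allyl on the amide nitrogen and a methyl on the aromatic ring; in this assay compound 2 gives 100 mg/kg. The two numbers lie within the usual scatter of each other, so the data show no difference between them that can be read.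

Compound 3 `C/C(C(=O)NC1CC1)=C(/C)c1ccc(C)cc1` has not yet been measured. It differs from compound 2 only in one place: cyclopropyl in place of allyl on an amide-type nitrogen. Among the compounds with values here, compound 1 already shows that a cyclopropyl on the amide nitrogen, here paired with the fluorinated ring, sits in the same region as compound 2, and no measured pair isolates this exchange. The expectation for the step from compound 2 to compound 3 in this assay is therefore a 1.1-fold higher number from compound 2 to compound 3 (0.02 log units; within the scatter), no change beyond the scatter. Compound 3 is thus estimated at 105 mg/kg, with a range from 60 mg/kg to 180 mg/kg.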

Compound 3, dose for half-maximal effect: 110 mg/kg
The estimate for compound 3 lay 1.0-fold (0.02 log units) below the measured number; the range from low to high includes it.
By their numbers in this assay, from the lowest: compounds 2, 1 and 3 (each within the scatter of the next).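

In this assay, the exchange on the amide nitrogen can now be read on its own, with the methyl-bearing aromatic ring held constant: cyclopropyl in place of allyl gives a 1.1-fold higher number from compound 2 to compound 3 (0.04 log units; within the scatter), so these two groups cannot be told apart at this position in this read-out. The new compound also isolates the substituent on the aromatic ring, with the cyclopropyl on the amide nitrogen held constant: methyl in place of fluoro gives no change at the digits printed from compound 1 to compound 3 (within the scatter), so each of the two exchanges separating compound 1 from compound 2 has now been read singly, and neither goes beyond the scatter. No measurement is available that would explain these results.

On these data alone, the nitrogen exchange has been read only with methyl on the aromatic ring, and the ring exchange only with cyclopropyl on the nitrogen, so it remains open whether either reads the same in the other setting. As far as these compounds go, it is also open how this assay responds to a longer chain or a carboxylic acid on the amide nitrogen, or to an amine on the aromatic ring.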